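The source may hold more compounds than are shown below. What is called first, only, known or untested is meant among the compounds shown, and "the series" means these compounds.

Working notes on the series. The shared core is carried by compound 1 `O=C(O)c1ccccc1-c1ccc(CCc2ncc(CC3CCCCC3)[nH]2)cc1`, compound 2 `CCCCc1cnc(C(Cc2ccc(-c3ccccc3C(=O)O)cc2)C(C)C)[nH]1` and compound 3 `CC(C)(C)CCc1cnc(CCc2ccc(-c3ccccc3C(=O)O)cc2)[nH]1`, all measured in an in vitro functional assay on cells for agonist activity at Bombesin receptor subtype-3 (Homo sapiens), read by luminescence and calcium flux; on this read-out higher numbers stand for an effect only at larger amounts of compound and lower numbers for an effect already at smaller amounts. Compound 1 gives 41 nM, and compound 3 gives 39 nM; the change between them, a 1.1-fold lower number from compound 1 to compound 3 (0.02 log units; within the scatter), concerns the substituent on the other side of the core and shows no effect beyond the scatter. Compound 2 stands apart: in this assay compound 2 gives 4620 nM, the highest of the three numbers. Among the compounds with values here, no single-point step joins compound 2 to compound 1 or compound 3, so only the two values can be compared, and compound 2 differs from both in more than one place.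

Compound 4 `CCCCc1cnc(C(CCCO)Cc2ccc(-c3ccccc3C(=O)O)cc2)[nH]1` is the next member, not yet measured. Against compound 2 the change is 3-hydroxypropyl in place of isopropyl on a saturated chain carbon bound to an aromatic carbon and a saturated chain carbon. Within the data shown here, none of the measured steps touches this branch on the saturated chain carbon bound to an aromatic carbon; the only measured step sits elsewhere and was within the scatter, so it gives no direction for the present change. Among the measured compounds shown here, with no bearing step, the expectation for compound 4 is set near compound 2, with a wide margin either way. The step from compound 2 to compound 4 is therefore estimated as a 1.5-fold lower number from compound 2 to compound 4 (0.19 log units; within the scatter). For compound 4 the value in this assay is estimated at 3000 nM, within a range from 500 nM to 15000 nM.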

Compound 4, half-maximal effective concentration: 1900 nM
Estimate against measurement, compound 4: 1.6-fold (0.20 log units) above, within the range that was stated.
By their numbers in this assay, from the lowest: compounds 3 and 1 (each within the scatter of the next); then compound 4; then compound 2.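

Within the data shown here, the branch on the saturated chain carbon bound to an aromatic carbon and a saturated chain carbon is the first place where a single change moves the number beyond the scatter in this assay, with a 2.4-fold lower number from compound 2 to compound 4 (0.39 log units; beyond the scatter) on going to 3-hydroxypropyl in place of isopropyl. Among these compounds, the only earlier step, on the substituent on the other side of the core, stayed within the scatter, so this position responds to its substituent where that one did not, although the step is marked as modest. The change brings in one more heavy atom, an oxygen, and with it a hydrogen-bond donor and acceptor, and no supporting measurement is available to assign the step to any of these.

The compounds shown leave open whether a plain propyl chain at this place would give the same step, which would separate the effect of the chain from that of its oxygen, and whether an amine or a carboxylic acid at the end of the chain would shift the number further. They also leave open whether the step holds when the butyl group on the other side of the core is exchanged for the cyclohexylmethyl or 3,3-dimethylbutyl groups of the other compounds.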